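A few compounds are considered here, and "the series" means these few. Any claim that something is new, unique, unknown or untested is made for them only; others in the source may bear on it.

Compound 1 `CC(=O)OC[C@H]1O[C@H](OCC(=O)NCc2cn(Cc3ccccc3)nn2)[C@H](O)[C@@H](OC(C)=O)[C@H]1OC(C)=O` is a peracetylated glycoside carrying a benzyl-substituted triazole, and in an ADME assay on HII4E cells (Mus musculus) for cytotoxicity, read by MTT assay, with a stated time of 48 h (a lower number here means a stronger inhibitor, a higher number a weaker inhibitor), compound 1 gives 879 ug/mL. Compound 2 `C=CCCCCn1cc(CNC(=O)CO[C@H]2O[C@H](COC(C)=O)[C@H](OC(C)=O)[C@H](OC(C)=O)[C@H]2O)nn1` keeps the same core with pent-4-en-1-yl in place of phenyl on a saturated chain carbon bound to an aromatic nitrogen, and in this assay compound 2 gives 63 ug/mL; this single change produced a 14-fold lower number from compound 1 to compound 2 (1.14 log units; beyond the scatter). Compound 3 `O=C(CO[C@H]1O[C@H](CO)[C@H](O)[C@H](O)[C@H]1O)NCc1cn(Cc2ccccc2)nn1` is the free sugar with the benzyl triazole; in this assay compound 3 gives 617 ug/mL, and the difference between its core and that of compound 1 is not broken down here. Compound 4 `C=CCCCCn1cc(CNC(=O)CO[C@H]2O[C@H](CO)[C@H](O)[C@H](O)[C@H]2O)nn1` differs from compound 3 by pent-4-en-1-yl in place of phenyl on a saturated chain carbon bound to an aromatic nitrogen, the same change at the same place. Given the step seen in a 14-fold lower number from compound 1 to compound 2 (1.14 log units; beyond the scatter), a step of an 8.8-fold lower number from compound 3 to compound 4 (0.95 log units; beyond the scatter) is expected from compound 3 to compound 4. Compound 4 is therefore estimated at 70 ug/mL, likely between 25 ug/mL and 250 ug/mL.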

Compound 4, half-maximal inhibitory concentration: 394 ug/mL
For compound 4 the middle estimate is 5.6-fold (0.75 log units) below the measured one, outside the stated range (above it).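

In this assay, the replacement of phenyl by pent-4-en-1-yl gives a 1.6-fold lower number from compound 3 to compound 4 (0.19 log units; within the scatter), so on the core of compound 3 the change has no effect that can be told from scatter. The change therefore does not carry over from one core to the other with the same size, since the large step on the core of compound 1 is absent here: the same change on two cores in this assay, a 14-fold lower number (1.14 log units; beyond the scatter) from compound 1 to compound 2 and a 1.6-fold lower number (0.19 log units; within the scatter) from compound 3 to compound 4, 8.9-fold (0.95 log units) apart, beyond the scatter of two such steps. For the compounds shown here, with only two cores, this does not show which feature of the cores sets the step, nor what the change would do on a third core.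

As far as these compounds go, it remains open how a core with only some of the acetyl groups would respond. Also open, from the compounds shown here alone, is whether a longer chain or a carboxylic acid at the same place would follow either step.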